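Bulkier bromothiophene arm on the shared amine core

This account rests on a few compounds, and the source may have more. Where it says the series, first, only, none or still open, it means among the compounds named here.

Compound 1 `CSc1ccc(CN[C@@H]2C[C@H]3C[C@@H]([C@H]2C)C3(C)C)s1` stands in an ADME assay on MDCK cells (Canis lupus familiaris) for cytotoxicity, read by microscopy, with a stated time of 48 h (a lower number here means that less compound is tolerated, a higher number that more compound is tolerated), at 25000 nM, level with compound 2 `CCc1csc(CN[C@@H]2C[C@H]3C[C@@H]([C@H]2C)C3(C)C)c1`, which gives 25000 nM; together these are the highest of the three numbers. Compound 3 `C[C@H]1[C@H](NCc2cc(Br)cs2)C[C@H]2C[C@@H]1C2(C)C` gives 6250 nM, and the step of a 4.0-fold lower number from compound 2 to compound 3 (0.60 log units; beyond the scatter) is the only one in the set that crosses the scatter. Compound 4 `C[C@H]1[C@H](NCc2ccc(-c3ccc(Br)s3)s2)C[C@H]2C[C@@H]1C2(C)C` differs from compound 1 by 5-bromothiophen-2-yl in place of methylsulfanyl on an aromatic carbon. For the measured compounds named here, the one measured step that bears on it is the bromo-for-ethyl exchange, where bromo entering cost a modest loss of tolerance; here bromo enters again, though on a second ring, so a step of similar size downward is expected, a 3.1-fold lower number from compound 1 to compound 4 (0.49 log units; beyond the scatter). Compound 4 is therefore estimated at 8000 nM, range 3000 nM to 25000 nM.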

Compound 4, minimum cytotoxic concentration: 780 nM
Compound 4: middle estimate off by 10-fold (1.01 log units), on the high side; the measured number lies below the stated range.
By their numbers in this assay, from the lowest: compound 4; then compound 3; then compounds 1 and 2 (each within the scatter of the next).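

On an aromatic carbon next to the ring sulfur, 5-bromothiophen-2-yl in place of methylsulfanyl gives a 32-fold lower number from compound 1 to compound 4 (1.51 log units; beyond the scatter) in this assay, so this position is sensitive to the change. That step is large, whereas a 4.0-fold lower number from compound 2 to compound 3 (0.60 log units; beyond the scatter) is modest, so the bromo-for-ethyl exchange did not foretell the size of a change that also brings a second aromatic ring. Nothing available explains the lower tolerated concentration.

The compounds shown do not separate the contribution of the bromine from that of the added ring. A plain thiophen-2-yl at this carbon would separate them.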